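From a saturated chain to a benzyl group

The source may hold more compounds than are shown below. What is called first, only, known or untested is meant among the compounds shown, and "the series" means these compounds.

In a functional assay on PC-3 cells (Homo sapiens) for inhibition, read by sulforhodamine B assay, with a stated time of 48 h (a lower number here means a stronger inhibitor, a higher number a weaker inhibitor), compound 3 (`O=C(CCCCCC(=O)Nc1ccc(NC(=O)Nc2ccc(Cl)c(C(F)(F)F)c2)cc1)NO`) stands at > 10000 nM and this is a limit, not a number. Compound 1 (`O=C(Nc1ccc(Nc2ncc(C(=O)NO)cn2)cc1)Nc1ccc(Cl)c(C(F)(F)F)c1`) reads > 10000 nM and this is also a limit. Compound 2 (`O=C(CCCCC(=O)Nc1ccc(NC(=O)Nc2ccc(Cl)c(C(F)(F)F)c2)cc1)NO`) reads > 10000 nM and this too is a limit. The measured set therefore shows the limit of > 10000 nM in this assay, at which 3 of the 3 values shown sit, and offers no actual number.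

Compound 4 (`O=C(Nc1ccc(NCc2ccc(C(=O)NO)cc2)cc1)Nc1ccc(Cl)c(C(F)(F)F)c1`) carries 4-(hydroxycarbamoyl)benzyl in place of (5-(hydroxycarbamoyl)pentyl)carbonyl on a nitrogen on an aromatic ring, and the counted change is 4-(hydroxycarbamoyl)benzyl in place of (5-(hydroxycarbamoyl)pentyl)carbonyl on a nitrogen on an aromatic ring at that place.

The group on that nitrogen has already been varied in a step that the two limits leave unreadable from compound 1 to compound 2 and a step that the two limits leave unreadable from compound 1 to compound 3 and a step that the two limits leave unreadable from compound 2 to compound 3 and none of these steps has a readable size. Going by a step that the two limits leave unreadable from compound 1 to compound 3 as the closest swap at that nitrogen, the estimated step is a number no higher from compound 3 to compound 4 (the limit leaves the size open) with nothing beyond the scatter expected in this assay and no direction favoured.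

For compound 4 the estimate is 10000 nM with an expected range of 3000 nM to 30000 nM and a report as a limit is the likeliest outcome.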

Compound 4, half-maximal inhibitory concentration: 3800 nM
Beside the measured number, compound 4's estimate is 2.6-fold (0.42 log units) above it; the measured number falls inside the stated range.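

In this assay compound 4 is the first compound shown that reads as an actual number and not as a limit, while the others stay at that limit: the limit of > 10000 nM in this assay, at which 3 of the 4 values shown sit. With 4-(hydroxycarbamoyl)benzyl on the nitrogen on an aromatic ring there is an at least 2.6-fold lower number from compound 3 to compound 4 (0.42 log units; beyond the scatter), along with an at least 2.6-fold lower number from compound 2 to compound 4 (0.42 log units; beyond the scatter) and an at least 2.6-fold lower number from compound 1 to compound 4 (0.42 log units; beyond the scatter), so this position can respond to the group placed on it. The steps among compounds 1, 2 and 3 cannot be read, and compound 1, whose 5-(hydroxycarbamoyl)pyrimidin-2-yl is also aromatic, remains a limit, so an aromatic ring in this group does not alone give a readable number.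

As far as these compounds go, the full size of all three steps stays open, since each starts from a limit. Also open, from the compounds shown here alone, is whether 4-(hydroxycarbamoyl)benzoyl on that nitrogen, or a carboxylic acid in place of the hydroxycarbamoyl of compound 4, would still give a readable number.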